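The source may hold more compounds than are shown below. What is called first, only, known or untested is meant among the compounds shown, and "the series" means these compounds.

Measured in a functional assay on A549 cells (Homo sapiens) for cytotoxicity, read by MTT assay, with a stated time of 48 h; a lower number here means a stronger inhibitor, a higher number a weaker inhibitor:
- compound 1 `O=c1ccoc2cc(OCc3cn(Cc4ccccc4)nn3)ccc12`: > 100000 nM, a limit
- compound 2 `O=c1ccoc2cc(OCc3cn(Cc4cccc(Br)c4)nn3)ccc12`: > 100000 nM, a limit
- compound 3 `O=c1ccoc2cc(OCc3cn(Cc4ccc(Cl)cc4Cl)nn3)ccc12`: 5260 nM

Compound 3 is the only one of these with an actual number. The other two rest on (the limit of > 100000 nM in this assay, at which 2 of the 3 values shown sit).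

Compound 4 `O=c1ccoc2cc(OCc3cn(Cc4ccc(F)cc4)nn3)ccc12` keeps the shared core and differs from compound 3 only on a saturated chain carbon bound to an aromatic nitrogen, where 4-fluorophenyl takes the place of 2,4-dichlorophenyl: 4-fluorophenyl in place of 2,4-dichlorophenyl on a saturated chain carbon bound to an aromatic nitrogen.

Among the compounds with values here, two measured steps bear on this change, and both bring in the 2,4-dichlorophenyl group. They are an at least 19-fold lower number from compound 1 to compound 3 (1.27 log units; beyond the scatter) and an at least 19-fold lower number from compound 2 to compound 3 (1.27 log units; beyond the scatter), and both are large. Compound 4 gives that group up, so a large step towards a higher number in this assay is expected, and the result may reach the limit of the assay. The 4-fluorophenyl group itself has not been measured, so the size of this step remains uncertain. The estimate amounts to an expected 6.7-fold higher number from compound 3 to compound 4 (0.82 log units; beyond the scatter). For compound 4 the estimated value is 35000 nM, with an expected range from 9000 nM to 100000 nM.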

Compound 4, half-maximal inhibitory concentration: > 100000 nM
Compound 4: a limit, no number; the forecaster's own chance of this, stated with the estimate: 40%; middle value at least 2.8-fold (0.45 log units) from the limit.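

In this assay compound 4 gives > 100000 nM, a limit and not a number. Putting 4-fluorophenyl in place of 2,4-dichlorophenyl on the saturated chain carbon bound to an aromatic nitrogen gives an at least 19-fold higher number from compound 3 to compound 4 (1.27 log units; beyond the scatter), so among these four compounds only the 2,4-dichlorophenyl group of compound 3 yields a measurable value, while the phenyl of compound 1, the 3-bromophenyl of compound 2 and now the 4-fluorophenyl of compound 4 do not. The steps among compound 1, compound 2 and compound 4 cannot be read because all three rest on the same limit: the limit of > 100000 nM in this assay, at which 3 of the 4 values shown sit.

From the compounds shown here alone, whether both chlorine atoms of compound 3 are needed, or one would be enough, remains open. It is also unknown how a ring carrying a methoxy group, or an amine at this place, would read.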